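The source may hold more compounds than are shown below. What is called first, only, known or untested is meant among the compounds shown, and "the series" means these compounds.

Compound 1, `NS(=O)(=O)NCC1CCN(c2cc(-c3cccc(Cl)c3)ncn2)CC1`, gives 47100 nM in a functional assay on MCF7 cells (Homo sapiens) for antiproliferative activity, read by sulforhodamine B assay, with a stated time of 48 h; on this read-out lower numbers stand for stronger inhibition of growth and higher numbers for weaker inhibition of growth. Compound 2, `COc1ccccc1-c1cc(N2CCC(CNS(N)(=O)=O)CC2)ncn1`, gives 10100 nM in this assay. Compound 3, `NS(=O)(=O)NCCC1CCN(c2cc(-c3cccc(Cl)c3)ncn2)CC1`, gives 31200 nM in this assay.

Two of these compounds share one change: 2-methoxyphenyl in place of 3-chlorophenyl on an aromatic carbon. That change produced a 4.7-fold lower number from compound 1 to compound 2 (0.67 log units; beyond the scatter). The cores of compound 1 and compound 3 differ as follows: (sulfamoylamino)methyl in place of sulfamoylamino on a saturated chain carbon bound to a saturated ring carbon. That difference produced a 1.5-fold lower number from compound 1 to compound 3 (0.18 log units; within the scatter), so the two cores behave alike in this assay.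

Compound 4, `COc1ccccc1-c1cc(N2CCC(CCNS(N)(=O)=O)CC2)ncn1`, has not yet been measured. It differs from compound 3 in this way: 2-methoxyphenyl in place of 3-chlorophenyl on an aromatic carbon. The place of the change is described in exactly the same words as for the change already measured, so it counts as the same change made on the other core. Within that pairing the expected step is a 4.5-fold lower number from compound 3 to compound 4 (0.65 log units; beyond the scatter), because the same change already gave a 4.7-fold lower number from compound 1 to compound 2 (0.67 log units; beyond the scatter) on a core that sits close by. Among the compounds with values here, the range is kept wide since only one example of the change exists. Compound 4 is therefore expected to give about 7000 nM in this assay, most likely between 2500 nM and 20000 nM.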

Compound 4, concentration for 50% growth inhibition: 69800 nM
Estimate against measurement, compound 4: 10-fold (1.00 log units) below, outside the stated range (above it).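

In this assay, within the data shown here, putting 2-methoxyphenyl in place of 3-chlorophenyl gave a 2.2-fold higher number from compound 3 to compound 4 (0.35 log units; beyond the scatter), so this change did not carry over from one core to the other, even in direction: the same change on two cores in this assay, a 4.7-fold lower number (0.67 log units; beyond the scatter) from compound 1 to compound 2 and a 2.2-fold higher number (0.35 log units; beyond the scatter) from compound 3 to compound 4, 10-fold (1.02 log units) apart, beyond the scatter of two such steps The core difference also depends on the aromatic group: with 2-methoxyphenyl in place it gave a 6.9-fold higher number from compound 2 to compound 4 (0.84 log units; beyond the scatter), while with 3-chlorophenyl the two cores behaved alike: the same change on two cores in this assay, a 1.5-fold lower number (0.18 log units; within the scatter) from compound 1 to compound 3 and a 6.9-fold higher number (0.84 log units; beyond the scatter) from compound 2 to compound 4, 10-fold (1.02 log units) apart, beyond the scatter of two such steps This shows that, across these four compounds, the effects of the two changes cannot simply be added, but with only one pair on each side it does not show why, or whether other compounds behave the same way.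

As far as these compounds go, it remains open which of the two directions would appear on a third core, such as one with a longer chain carrying the sulfamoylamino group. From the compounds shown here alone, it is also open how a plain phenyl group in place of either aromatic group, or an amine in place of sulfamoylamino, would behave across these cores.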